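Hydrazone amide series: trimming a methoxy on the carbonyl-side ring

A few compounds are considered here, and "the series" means these few. Any claim that something is new, unique, unknown or untested is made for them only; others in the source may bear on it.

Working notes on the carbonyl-side aromatic ring. Three compounds have numbers in a functional assay on the whole organism (strain A/J) for inhibition, with Mus musculus as the target, with stated times of 1 h and 18 h, at a dose of 100 umol/kg by the oral route; on this read-out lower numbers stand for less inhibition and higher numbers for more inhibition at the one dose given (going by the name of the read-out). Compound 1 `COc1ccc(/C=N/N(C)C(=O)c2ccccc2OC)cc1OC` gives 99%. Compound 2 `COc1cccc(C(=O)N(C)/N=C/c2ccc(OC)c(OC)c2)c1` gives 38%. Compound 3 `COc1ccc(/C=N/N(C)C(=O)c2ccc(OC)c(OC)c2)cc1OC` gives 65%, which places it second of the three: the step of a number 61 percentage points lower from compound 1 to compound 2 (beyond the scatter) is the large one, and the step of a number 27 percentage points higher from compound 2 to compound 3 (beyond the scatter) is modest, so compound 3 sits between compound 2 and compound 1, beyond the scatter from each.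

Compound 4 `COc1ccc(C(=O)N(C)/N=C/c2ccc(OC)c(OC)c2)cc1` is not yet measured. It differs from compound 3 by hydrogen in place of methoxy on an aromatic carbon. For the measured compounds named here, only one measured step touches the same ring in a comparable way: the step of a number 27 percentage points higher from compound 2 to compound 3 (beyond the scatter), where a methoxy entering gave a modest gain. The present change takes a methoxy away, at a different position of the ring, so that step offers only an indirect guide, and the large step of a number 61 percentage points lower from compound 1 to compound 2 (beyond the scatter) shows that the numbers on this read-out move strongly with the methoxy pattern on this ring. A fall of modest size from compound 3 is expected, as a number 15 percentage points lower from compound 3 to compound 4 (beyond the scatter), with wide uncertainty. Compound 4 is therefore estimated at 50%, in a range from 20% to 85%.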

Compound 4, a percentage reported as inhibition, in the whole organism at one dose (the size of the read-out at that dose, not a potency): 45%
The estimate for compound 4 lay 5 percentage points above the measured number, and the stated range covers the measured number.
By their numbers in this assay, from the lowest: compounds 2 and 4 (each within the scatter of the next); then compound 3; then compound 1.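

In this assay, hydrogen in place of the methoxy that sits ortho to a methoxy group and meta to a large group gives a modest loss (a number 20 percentage points lower from compound 3 to compound 4 (beyond the scatter)), so this methoxy counts on the read-out even with the other methoxy kept. For the compounds shown here, with a single methoxy on the ring, the 3-methoxyphenyl and 4-methoxyphenyl compounds cannot be told apart (a number 7 percentage points higher from compound 2 to compound 4 (within the scatter)), which the earlier compounds could not show. The 4-methoxyphenyl compound also falls far short of the 2-methoxyphenyl compound (a number 54 percentage points lower from compound 1 to compound 4 (beyond the scatter)), so among the compounds with a single methoxy on this ring, only the 2-methoxyphenyl compound stands apart. Nothing in hand gives a reason for any of these differences.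

The compounds shown leave open whether the methoxy itself matters in the 2-methoxyphenyl compound or whether another group there, such as a hydroxyl, an amine or a chlorine atom, would serve as well. They also leave open how the ring behaves with no substituent at all, and whether the gaps seen at this one dose would hold at other doses.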